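The source may report more compounds than this note shows. Statements on the series, on what has been measured and on what is new or still open speak of the compounds shown alone.

Compound 3 `Cc1cc(O)c(C2=NN(c3ccc(S(N)(=O)=O)cc3)C(/C=C/c3ccccc3)C2)cc1Cl` gives 4320 nM in a functional assay on IGROV-1 cells (Homo sapiens) for antiproliferative activity, with a stated time of 48 h (on this read-out higher numbers stand for weaker inhibition of growth and lower numbers for stronger inhibition of growth), and among the three measured compounds it stands at the highest number. Compound 1 `Cc1cc(O)c(C2=NN(c3ccc(S(N)(=O)=O)cc3)C(c3ccccc3O)C2)cc1Cl` gives 1630 nM and compound 2 `Cc1cc(O)c(C2=NN(c3ccc(S(N)(=O)=O)cc3)C(c3ccccc3Cl)C2)cc1Cl` gives 2580 nM in this assay. Compound 4 `COc1ccc(C2CC(c3cc(Cl)c(C)cc3O)=NN2c2ccc(S(N)(=O)=O)cc2)cc1OC` has not been measured; its change from compound 3 is 3,4-dimethoxyphenyl in place of 2-phenylethenyl on a saturated ring carbon. Among the compounds with values here, the steps that bear on it are those at the same saturated ring carbon: a 2.7-fold higher number from compound 1 to compound 3 (0.42 log units; beyond the scatter) and a 1.7-fold higher number from compound 2 to compound 3 (0.22 log units; within the scatter). Both move from an aromatic group to the 2-phenylethenyl group and both raise the number, one modestly beyond the scatter and one within it. Reversing that direction, toward another aromatic group, the 3,4-dimethoxyphenyl, compound 4 is therefore expected to show a lower number than compound 3, by a step of about a 2.2-fold lower number from compound 3 to compound 4 (0.33 log units; beyond the scatter), though no measured step involves a 3,4-dimethoxyphenyl group and the size is uncertain. Compound 4 is estimated at 2000 nM, with a range from 900 nM to 4500 nM.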

Compound 4, concentration for 50% growth inhibition: 2340 nM
For compound 4 the middle estimate is 1.2-fold (0.07 log units) below the measured one; low and high end bracket the measured number.
By their numbers in this assay, from the lowest: compounds 1, 4, 2 and 3 (each within the scatter of the next, the first and the last beyond it).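

Compound 4 shows that a third aromatic group at this saturated ring carbon, the 3,4-dimethoxyphenyl, cannot be told apart from the 2-chlorophenyl or 2-hydroxyphenyl groups in this assay: both a 1.1-fold lower number from compound 2 to compound 4 (0.04 log units; within the scatter) and a 1.4-fold higher number from compound 1 to compound 4 (0.16 log units; within the scatter) lie within the scatter. Exchanging the 2-phenylethenyl group for it, a 1.8-fold lower number from compound 3 to compound 4 (0.27 log units; within the scatter), also stays within the scatter, so among the four compounds only a 2.7-fold higher number from compound 1 to compound 3 (0.42 log units; beyond the scatter) lies beyond it. No evidence is at hand that bears on these results.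

The compounds shown leave open whether a group without an aromatic ring at this carbon, such as a short alkyl chain, or a phenyl ring carrying an amine or a carboxylic acid, would move the number beyond the scatter. They also leave open whether a single methoxy group on the phenyl ring would give a similar number.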